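Tert-butyl in place of propyl on a sulfur

This account rests on a few compounds, and the source may have more. Where it says the series, first, only, none or still open, it means among the compounds named here.

Compound 1 `C=CCSS/C=C/C[S+]([O-])CCC`: 26700 nM
Compound 2 `C=CCSS/C=C\C[S+]([O-])CCC`: 17000 nM

Within the data shown here, in a functional assay on cells (Fibroblast) for antiproliferative activity (on this read-out higher numbers stand for weaker inhibition and lower numbers for stronger inhibition), compound 1 gives 26700 nM, and its only measured neighbour, compound 2, gives 17000 nM. These two values lie within the scatter of each other, so neither can be ranked above the other.

Compound 3 `C=CCSS/C=C/C[S+]([O-])C(C)(C)C` has not been measured. It differs from compound 1 at one place: tert-butyl in place of propyl on a sulfur.

Among the measured compounds shown here, the only measured step, a 1.6-fold lower number from compound 1 to compound 2 (0.20 log units; within the scatter), alters the geometry of a double bond and leaves the propyl in place, so it bears on this change only loosely. Nothing measured points in either direction, so no shift beyond the scatter is expected in this assay. The expected step is a 1.2-fold lower number from compound 1 to compound 3 (0.06 log units; within the scatter). For compound 3 the estimated value is 23000 nM, with an expected range of 10000 nM to 52000 nM.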

Compound 3, half-maximal inhibitory concentration: 33100 nM
Compound 3: the middle estimate sits 1.4-fold (0.16 log units) below what was measured; the measured number falls inside the stated range.
By their numbers in this assay, from the lowest: compounds 2, 1 and 3 (each within the scatter of the next).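

In this assay, tert-butyl in place of propyl on the sulfur gives a 1.2-fold higher number from compound 1 to compound 3 (0.09 log units; within the scatter) and so stays within the scatter. Among these compounds, the earlier step changed only the geometry of a double bond, so this is the first reading on the group at this sulfur: here, a swap from 3 heavy atoms to 4 does not separate the two compounds. No available fact explains this outcome, as the only one on record concerns the double bond that differs between compound 1 and compound 2.

As far as these compounds go, it remains open whether a different kind of group at this sulfur, such as an amine, a carboxylic acid or a longer chain, would move the number beyond the scatter. From the compounds shown here alone, it is also open whether tert-butyl would behave the same way with the Z double bond of compound 2.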